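Notes on the aryl change from compound 1 to compound 4

A few compounds are considered here, and "the series" means these few. Any claim that something is new, unique, unknown or untested is made for them only; others in the source may bear on it.

In an assay on HEK293 cells for activation of potassium channel subfamily T member 1 (Homo sapiens), read by thallium flux (on this read-out lower numbers stand for an effect already at smaller amounts and higher numbers for an effect only at larger amounts of compound), compound 1 `COc1ccc(NC(=O)CN2CCN(S(=O)(=O)N3CCC(C)CC3)CC2)cc1` reaches only the assay limit, > 10000 nM, so its own number is not known. Compound 2 `CC1CCN(S(=O)(=O)N2CCN(CC(=O)Nc3cccc(F)c3)CC2)CC1` gives 4600 nM in this assay. Within the data shown here, compound 3 `COc1ccc(Cl)cc1NC(=O)CC1CCN(S(=O)(=O)N2CCC(C)CC2)CC1`, built on a different core, gives 9300 nM in this assay; no single-point step connects it to compound 1. Compound 4 `CC1CCN(S(=O)(=O)N2CCN(CC(=O)Nc3cccc(Cl)c3)CC2)CC1` has not yet been measured. It differs from compound 1 in one place: 3-chlorophenyl in place of 4-methoxyphenyl on an amide-type nitrogen. Among the measured compounds shown here, the one measured step that bears on this change is an at least 2.1-fold lower number from compound 1 to compound 2 (0.33 log units; beyond the scatter), which puts a halogen-bearing ring in the same place; its size rests on the limit of > 10000 nM in this assay, at which 1 of the 3 values shown sits, and is therefore itself only a lower bound. A chlorine in place of the fluorine is expected to give a step of the same direction and at least the same size, an at least 2.8-fold lower number from compound 1 to compound 4 (0.45 log units; beyond the scatter). Compound 4 is accordingly expected to give about 3500 nM in this assay, with a range of 1200 nM to 10000 nM, the upper end reflecting that the starting point is a limit.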

Compound 4, half-maximal effective concentration: 7600 nM
The estimate for compound 4 lay 2.2-fold (0.34 log units) below the measured number, and the stated range covers the measured number.
By their numbers in this assay, from the lowest: compounds 2, 4 and 3 (each within the scatter of the next, the first and the last beyond it). At a limit, above all of these: compound 1.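

In this assay the chlorine gives a 1.7-fold higher number from compound 2 to compound 4 (0.22 log units; within the scatter), so chloro in place of fluoro on this aromatic carbon cannot be told apart from the fluoro compound. The change from the 4-methoxyphenyl ring gives an at least 1.3-fold lower number from compound 1 to compound 4 (0.11 log units; that floor lies within the scatter), so the step beyond the scatter seen with the 3-fluorophenyl ring, an at least 2.1-fold lower number from compound 1 to compound 2 (0.33 log units; beyond the scatter), is not established for the 3-chlorophenyl ring. Both steps are floors only, because compound 1 stands at a limit: the limit of > 10000 nM in this assay, at which 1 of the 4 values shown sits.

Still open, going by these compounds, is how far the number of compound 1 lies past that limit, and so whether the 3-chlorophenyl step is in truth beyond the scatter. Also open, on these data alone, is how an unsubstituted phenyl, 3-methoxyphenyl, 4-chlorophenyl or 3-bromophenyl would read on the same amide-type nitrogen.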